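This account rests on a few compounds, and the source may have more. Where it says the series, first, only, none or still open, it means among the compounds named here.

Measured compounds, each with its value in a functional assay on ileum (Cavia porcellus) for antagonist activity at cysteinyl leukotriene receptor (Homo sapiens); a lower number here means a stronger inhibitor, a higher number a weaker inhibitor:

- compound 1 `CCC(CC)(CC(=O)Nc1cccc(OCc2ccc3cc(F)c(F)cc3n2)c1)C(=O)O`: 0.5 nM
- compound 2 `CCC(CC)(CC(=O)Nc1cccc(OCc2ccc3ccc(Br)cc3n2)c1)C(=O)O`: 4 nM
- compound 3 `CCC(CC)(CC(=O)Nc1cccc(OCc2ccc3cc(C)c(C)cc3n2)c1)C(=O)O`: 11 nM

Within this set of three, compound 2 holds the second-highest number. Its value sits between that of compound 1 and that of compound 3, and both of those gaps lie beyond the usual scatter of this assay, so compound 2 is neither the strongest nor the weakest of the three on these numbers.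

Compound 4 `CCC(CC)(CC(=O)Nc1cccc(OCc2ccc3ccc(C(C)=O)cc3n2)c1)C(=O)O` keeps the shared core and the side chain of compound 2 and alters only the substituent on the fused ring: acetyl in place of bromo on an aromatic carbon. Among the measured compounds shown here, no measured pair in this set shows that exact exchange, so no direct precedent exists for its effect. What the three values do show is that changing the substituents on that fused ring moves the number well beyond the scatter in either direction.

The step in this assay from compound 2 to compound 4 is expected to be a modest rise in the number, a 2.0-fold higher number from compound 2 to compound 4 (0.30 log units; within the scatter), with wide uncertainty. The estimate for compound 4 is 8 nM, with a range from 2 nM to 40 nM.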

Compound 4, half-maximal inhibitory concentration: 2500 nM
Compound 4: the middle estimate sits 310-fold (2.49 log units) below what was measured; measured number outside the range, above it.
By their numbers in this assay, from the lowest: compound 1; then compound 2; then compound 3; then compound 4.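

In this assay, acetyl in place of bromo on an aromatic carbon gives a 630-fold higher number from compound 2 to compound 4 (2.80 log units; beyond the scatter) with the rest of the structure unchanged. Among the compounds shown here, the earlier compounds offered no single-change step, so this is the first direct reading at this position, and it shows that the position does not accept every substituent: one exchange here moves the number by a large step, and it does so towards a weaker inhibitor. No measurement available here accounts for the size of this step.

As far as these compounds go, whether the loss requires the carbonyl of the acetyl group or follows from replacing one heavy atom with three stays open. An ethyl group or a methoxy group on this same aromatic carbon would help to separate those two readings.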